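This account rests on a few compounds, and the source may have more. Where it says the series, first, only, none or still open, it means among the compounds named here.

Working notes on the series. Compound 1 `COc1ccc(CN(C(=O)CSc2nc3ccccc3s2)c2cc(OC)c(OC)c(OC)c2)cc1O`, compound 2 `COc1ccc(CN(C(=O)CSc2nc3ccccc3s2)c2cc(OC)c(OC)c(OC)c2)cc1N` and compound 3 `COc1ccc(CN(C(=O)CSc2nc3ccccc3s2)c2cc(OC)c(OC)c(OC)c2)cc1[N+](=O)[O-]` share one core and differ only in the group on the aromatic carbon ortho to a methoxy group. In a functional assay on MGC-803 cells (Homo sapiens) for antiproliferative activity, read by MTT assay, with a stated time of 48 h (a lower number here means a stronger inhibitor, a higher number a weaker inhibitor), compound 1 gives 35 nM, compound 2 gives 84 nM and compound 3 gives 682 nM, the highest of the three numbers, with compound 2 nearest and compound 1 furthest. The measured steps are a 2.4-fold higher number from compound 1 to compound 2 (0.38 log units; beyond the scatter), a 19-fold higher number from compound 1 to compound 3 (1.29 log units; beyond the scatter) and an 8.1-fold higher number from compound 2 to compound 3 (0.91 log units; beyond the scatter).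

Compound 4 `COc1ccc(CN(C(=O)CSc2nc3ccccc3s2)c2cc(OC)c(OC)c(OC)c2)cc1OC` has not been measured. Its difference from compound 3 is methoxy in place of nitro on an aromatic carbon. Within the data shown here, the steps that bear on it are the two ending at compound 3, a 19-fold higher number from compound 1 to compound 3 (1.29 log units; beyond the scatter) and an 8.1-fold higher number from compound 2 to compound 3 (0.91 log units; beyond the scatter), both beyond the scatter and both showing the nitro compound as the weakest of the three; no measured step places a methoxy at this position, so the hydroxy and amino numbers serve only as an indirect anchor. Replacing nitro is therefore expected to give a lower number, most likely between the amino and nitro compounds. The step expected in this assay is a 4.5-fold lower number from compound 3 to compound 4 (0.66 log units; beyond the scatter). Compound 4 is estimated at 150 nM, with a range from 40 nM to 600 nM.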

Compound 4, half-maximal inhibitory concentration: 34100 nM
Compound 4: middle estimate off by 230-fold (2.36 log units), on the low side; measured number above the stated range.
By their numbers in this assay, from the lowest: compound 1; then compound 2; then compound 3; then compound 4.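

In this assay methoxy is the weakest of the four groups at this position: the steps are a 50-fold higher number from compound 3 to compound 4 (1.70 log units; beyond the scatter) and a 410-fold higher number from compound 2 to compound 4 (2.61 log units; beyond the scatter) and a 970-fold higher number from compound 1 to compound 4 (2.99 log units; beyond the scatter) and all lie beyond the scatter. The last of these is only methyl in place of hydrogen on an oxygen on an aromatic ring, yet it is a larger step than the one from hydroxy to nitro, so the earlier order of hydroxy, amino and nitro gave no sign of where methoxy would fall. Nothing measured here accounts for this order.

The compounds shown leave open whether a longer chain on this oxygen, such as ethoxy, gives a number as high as compound 4 does. They also leave open where a fluorine atom, a carboxylic acid or an acetamide on the same aromatic carbon would fall.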